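The source may hold more compounds than are shown below. What is called first, only, known or untested is meant among the compounds shown, and "the series" means these compounds.

Two compounds that share one core have been run through an ADME assay on PC-3 cells (Homo sapiens) for cytotoxicity, read by WST assay, tested at 100 uM; a lower number here means less inhibition, a higher number more inhibition at the concentration tested (going by the name of the read-out). Compound 1 `COC(=O)c1cccc(NC(=O)C2CCCN(C(=O)c3cc(C(F)(F)F)cc(C(F)(F)F)c3)C2)c1` gives 0% in this assay, and compound 2 `O=C(Nc1ccc(Cl)cc1)C1CCCN(C(=O)c2cccc(-c3cnco3)c2)C1` gives 0% in this assay. Compound 1 thus stands level with compound 2 at the digits shown; the two values lie within the usual scatter of each other, so neither compound can be called the more or the less inhibiting one. Both read as essentially no inhibition at the concentration tested.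

Compound 3 `COc1cccc(NC(=O)C2CCCN(C(=O)c3cc(C(F)(F)F)cc(C(F)(F)F)c3)C2)c1` has not yet been measured in this assay. It differs from compound 1 in a single place: methoxy in place of methoxycarbonyl on an aromatic carbon. Going by the values given here, no pair of measured compounds isolates this change, so no measured step exists to lean on. What is known is that compound 1 gives 0% and compound 2 gives 0%, both reading as essentially no inhibition. On that basis the step from compound 1 to compound 3 is expected to be a number 2 percentage points higher from compound 1 to compound 3 (within the scatter), that is, none beyond the scatter. Compound 3 is therefore estimated at 2%, within a range from -8% to 15%.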

Compound 3, a percentage reported as inhibition, at one concentration (the size of the read-out at that concentration, not a potency): 0%
For compound 3 the middle estimate is 2 percentage points above the measured one, and the stated range covers the measured number.
By their numbers in this assay, from the lowest: compounds 1, 2 and 3 (each within the scatter of the next).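

Putting methoxy in place of methoxycarbonyl on an aromatic carbon, meta to a large group, gives no change at the digits printed from compound 1 to compound 3 (within the scatter) in this assay. Going by these compounds alone, compounds 1 and 2 differ in more than one place, so this is the first reading of a single change at this position: with either group there, the compound shows essentially no inhibition at the concentration tested, and the smaller methoxy group leaves the reading as it was. Nothing at hand explains this result.

Because all the compounds shown read as essentially no inhibition, they cannot show whether this position would matter in a compound that does inhibit, as a flat reading can hide differences between groups. On these data alone, whether an amine or a carboxylic acid on this aromatic carbon would also leave the reading at essentially no inhibition remains open.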